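The compounds below may be only part of what the source reports. "The series", "measured", "known", "first", "only" and "open" are said of these compounds alone.

Measured compounds:
- compound 1 `COc1cc(F)c(CN2C(=O)N(c3ccc(OC)c(OC)c3)S(=O)(=O)c3ccccc32)c(Cl)c1` — 0.398 nM
- compound 2 `COc1cc(N2C(=O)N(Cc3c(F)cc(F)cc3Cl)c3ccccc3S2(=O)=O)cnc1OC` — 39.8 nM

In an assay on isolated protein for displacement of a labelled ligand from Orexin/Hypocretin receptor type 1 (Homo sapiens), with a stated time of 90 min (on this read-out higher numbers stand for weaker inhibition and lower numbers for stronger inhibition), compound 1 gives 0.398 nM, the lowest of the two numbers shown, and compound 2 gives 39.8 nM, a number far beyond the usual scatter; no single-change step links these two, so their values can only be placed side by side.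

Compound 3 `COc1ccc(N2C(=O)N(Cc3ccccc3)c3ccccc3S2(=O)=O)cc1OC` has not been measured. It differs from compound 1 in one place: phenyl in place of 2-chloro-6-fluoro-4-methoxyphenyl on a saturated chain carbon bound to an amide-type nitrogen in a ring. The benzyl group of compound 1 is thereby stripped of its chloro, fluoro and methoxy groups. Among the compounds with values here, nothing among the measured compounds isolates this change, so the step is a guess: compound 3 is expected to be weaker than compound 1, with the step from compound 1 to compound 3 estimated at a 50-fold higher number from compound 1 to compound 3 (1.70 log units; beyond the scatter), beyond the scatter. Compound 3 is accordingly estimated at 20 nM, within a range from 3 nM to 150 nM.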

Compound 3, inhibition constant: 2000 nM
For compound 3 the middle estimate is 100-fold (2.00 log units) below the measured one, outside the stated range (above it).
By their numbers in this assay, from the lowest: compound 1; then compound 2; then compound 3.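

Stripping the benzyl group of compound 1 down to a bare benzyl gives, in this assay, a 5000-fold higher number from compound 1 to compound 3 (3.70 log units; beyond the scatter) and so a large loss of inhibition. Within the data shown here, this is the first direct sign that the groups on this ring matter greatly, since the two earlier compounds differed in more than one place and could only be set side by side. The data give no reason for the size of this step.

Because chloro, fluoro and methoxy all leave in this single change, the compounds shown cannot tell whether one of them carries most of the step or whether all three contribute. Also open, going by these compounds, is how this position would respond to other groups, such as a trifluoromethyl group on the ring or a longer chain like phenylethyl in place of the benzyl.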